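This account rests on a few compounds, and the source may have more. Where it says the series, first, only, none or still open, it means among the compounds named here.

Compound 1 `COc1ccc(-c2nc(C)nn2-c2cccc(C(=O)NCCCCCc3ccccc3)c2)cc1`: > 20000 nM, a limit of the assay
Compound 2 `COc1ccc(-c2ncnn2-c2cccc(C(=O)NCCCCc3ccccc3)c2)cc1`: > 20000 nM, a limit of the assay
Compound 3 `CCOc1ccc(-c2nc(CC)nn2-c2cccc(C(=O)NCCCCc3ccccc3)c2)cc1`: 16800 nM

All three compounds were tested in a functional assay on PANC-1 cells (Homo sapiens), read by microscopy, crystal violet staining and transwell migration, with a stated time of 18 h, in the presence of a further agent that is not named here; a higher number here means a weaker inhibitor, a lower number a stronger inhibitor. Compound 1 reads > 20000 nM, which is a limit and not a number. Compound 2 reads > 20000 nM, which is also a limit. The set is therefore dominated by the limit of > 20000 nM in this assay, at which 2 of the 3 values shown sit. Among the measured compounds shown here, compound 3 stands alone as the only compound with an actual number, at 16800 nM.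

The next compound, compound 4 `CCc1nc(-c2ccc(OC(F)(F)F)cc2)n(-c2cccc(C(=O)NCCCCc3ccccc3)c2)n1`, differs from compound 3 in one place: 4-ethoxyphenyl becomes 4-(trifluoromethoxy)phenyl. The difference is trifluoromethyl in place of ethyl on an oxygen on an aromatic ring, with trifluoromethyl in place of ethyl on an oxygen on an aromatic ring. For the measured compounds named here, no measured pair in this small set isolates a single change, so the data give no direct size for such a step. In this assay, no step beyond the usual scatter is expected, and no direction is favoured. Going by the values given here, this expectation rests on compound 3 at 16800 nM, the one number available. A reading that stops at the limit would be no surprise. The estimated step is a 1.1-fold lower number from compound 3 to compound 4 (0.05 log units; within the scatter). For compound 4 the expected value is 15000 nM, with an estimated range of 7000 nM to 20000 nM.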

Compound 4, half-maximal inhibitory concentration: 640 nM
Compound 4: middle estimate off by 23-fold (1.37 log units), on the high side; the whole stated range lies above it.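

The oxygen on the aromatic ring stays in place and only the group it carries changes, from ethyl to trifluoromethyl, yet in this assay this single swap brings a 26-fold lower number from compound 3 to compound 4 (1.42 log units; beyond the scatter). Among the compounds shown here, the group on that oxygen is therefore a place where this read-out can respond strongly to a small edit, which the earlier compounds could not show, as no two of them differ in one place only. Compound 4 also gives the series its first value far from the limit of the assay, where the other compounds mostly sat, so there is now room to see later changes in either direction: the limit of > 20000 nM in this assay, at which 2 of the 4 values shown sit.

This finding rests on one pair in one assay, so it cannot tell whether the gain depends on all three fluorine atoms or on the trifluoromethyl group as a whole. Difluoromethyl or a longer chain such as propyl on the same oxygen would help to separate these readings, and a chlorine atom in place of the whole trifluoromethoxy group would show whether the oxygen is needed at all.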